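The source may hold more compounds than are shown below. What is called first, only, known or untested is meant among the compounds shown, and "the series" means these compounds.

Measured in an ADME assay on HUVEC cells (Homo sapiens) for inhibition, read by CCK-8 assay, with a stated time of 24 h, in the presence of a further agent that is not named here; on this read-out lower numbers stand for stronger inhibition and higher numbers for weaker inhibition:
- Compound 1 `O=C1Nc2ccc(F)cc2C1=Cc1ccc(-c2cn(-c3ccccc3)nn2)cc1`: 13700 nM
- Compound 2 `Cc1cccc(-n2cc(-c3ccc(/C=C4\C(=O)Nc5ccc(F)cc54)cc3)nn2)c1`: 9880 nM
- Compound 3 `O=C1Nc2ccc(F)cc2/C1=C/c1ccc(-c2cn(-c3ccccc3F)nn2)cc1`: 14400 nM

Compound 1 has no clear rank in this small set, since its number lies within the usual scatter of both others. Compound 4 `O=C1Nc2ccc(F)cc2C1=Cc1ccc(-c2cn(-c3ccc(Cl)cc3)nn2)cc1` differs from compound 1 by one change, chloro in place of hydrogen on an aromatic carbon, which turns phenyl into 4-chlorophenyl (chloro in place of hydrogen on an aromatic carbon). For the measured compounds named here, no measured compound carries chloro. The closest evidence is a swap of the group on the aromatic nitrogen, a 1.5-fold higher number from compound 2 to compound 3 (0.16 log units; within the scatter), and that step stayed within the scatter. No step beyond the scatter is therefore expected in this assay. The estimated step is a 1.2-fold lower number from compound 1 to compound 4 (0.10 log units; within the scatter). For compound 4 the estimated value is 11000 nM, with an expected range of 5500 nM to 22000 nM.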

Compound 4, half-maximal inhibitory concentration: 19600 nM
The estimate for compound 4 lay 1.8-fold (0.25 log units) below the measured number; measured number inside the range.
By their numbers in this assay, from the lowest: compounds 2, 1, 3 and 4 (each within the scatter of the next).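

Compound 4 is the only compound shown with a group at this place on the outer ring, para to a large group, so it gives the first direct reading there. In this assay the change from phenyl to 4-chlorophenyl gives a 1.4-fold higher number from compound 1 to compound 4 (0.16 log units; within the scatter) and so does not separate the two compounds. Nothing measured here bears on this result.

From the compounds shown here alone, whether a larger change at this carbon, such as an amine or a carboxylic acid, would give a step beyond the scatter remains open. Also open, going by these compounds, is whether any group here could bring the number clearly down.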